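Pyrazole for Thiophene in an Adrenergic Agonist Series

A few compounds are considered here, and "the series" means these few. Any claim that something is new, unique, unknown or untested is made for them only; others in the source may bear on it.

Measured so far:
Compound 1, `c1csc(-c2ccccc2OCC2=NCCN2)c1`, gives 1 nM in a functional assay for activation of Alpha-1A adrenergic receptor (Homo sapiens), read by calcium flux; a lower number here means that less compound is needed, a higher number that more compound is needed for the effect.
Compound 2, `c1ccc(-c2ccoc2)c(OCC2=NCCN2)c1`, gives 0.501 nM.
Compound 3, `c1ccc(-c2ccsc2)c(OCC2=NCCN2)c1`, gives 0.251 nM.

All three share one core and differ only in the five-membered aromatic ring attached to it. Compound 3 stands at the lowest of the three numbers: the step of a 2.0-fold lower number from compound 2 to compound 3 (0.30 log units; within the scatter) stays within the scatter, whereas a 4.0-fold lower number from compound 1 to compound 3 (0.60 log units; beyond the scatter) lies beyond it, and a 2.0-fold lower number from compound 1 to compound 2 (0.30 log units; within the scatter) is again within it. Swapping one such ring for another has so far moved the result little.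

Compound 4, `Cn1nccc1-c1ccccc1OCC1=NCCN1`, carries a different ring: 1-methyl-1H-pyrazol-5-yl in place of thiophen-3-yl on an aromatic carbon. Among the compounds with values here, none of the measured steps involves a ring with two hetero atoms or a methyl group, so the closest guide is simply that ring swaps here have stayed small. A modest rise in this assay is therefore expected, a 6.0-fold higher number from compound 3 to compound 4 (0.78 log units; beyond the scatter), with wide uncertainty. For compound 4 the estimate is 1.5 nM, with a range from 0.3 nM to 8 nM.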

Compound 4, half-maximal effective concentration: 39.8 nM
Compound 4: middle estimate off by 27-fold (1.42 log units), on the low side; the whole stated range lies below it.
By their numbers in this assay, from the lowest: compounds 3, 2 and 1 (each within the scatter of the next, the first and the last beyond it); then compound 4.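

At the position on the aromatic carbon, ortho to a group of 7 heavy atoms, compounds 1 to 3 made the five-membered ring look freely exchangeable, but compound 4 shows that it is not: in this assay the change is a 160-fold higher number from compound 3 to compound 4 (2.20 log units; beyond the scatter) and far exceeds any earlier step. The gap remains large against the other two rings, at a 79-fold higher number from compound 2 to compound 4 (1.90 log units; beyond the scatter) and a 40-fold higher number from compound 1 to compound 4 (1.60 log units; beyond the scatter) so the 1-methyl-1H-pyrazol-5-yl ring stands apart from all three rings measured before it. No measurement at hand accounts for this gap.

The new ring brings two nitrogens and a methyl group at once, so the compounds shown cannot separate the effect of one from the other. A pyrazole without the methyl group, or a methyl-bearing thiophene, would pull these two changes apart.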